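The source may hold more compounds than are shown below. What is called first, only, known or untested is meant among the compounds shown, and "the series" means these compounds.

Compound 1 `C[C@@]1(O)CC(=O)OC(CSc2nc(-c3ccccc3)c(-c3ccccc3)[nH]2)C1`: in an assay on microsomes from liver for inhibition of sterol O-acyltransferase 1 (Rattus norvegicus) (a higher number here means a weaker inhibitor, a lower number a stronger inhibitor), compound 1 gives 170 nM. Compound 2 `C[C@]1(O)CC(=O)OC(CSc2nc(-c3ccccc3)c(-c3ccccc3)[nH]2)C1`: in this assay compound 2 gives 140 nM.

Compound 2 holds the lower of the two numbers, yet the step of a 1.2-fold lower number from compound 1 to compound 2 (0.08 log units; within the scatter) is within the scatter, so the two are not told apart. Compound 3 `CC1=CC(=O)OC(CSc2nc(-c3ccccc3)c(-c3ccccc3)[nH]2)C1` differs from compound 2 by a group of 8 heavy atoms (6 carbon, 2 oxygen; one six-membered non-aromatic ring with 1 hetero atom) in place of a group of 9 heavy atoms (6 carbon, 3 oxygen; one six-membered non-aromatic ring with 1 hetero atom), on a saturated chain carbon bound to a sulfur. Going by the values given here, the only measured step, a 1.2-fold lower number from compound 1 to compound 2 (0.08 log units; within the scatter), concerns the configuration at a ring carbon of the group that leaves, where the fact that one of compounds 1 and 2 is drawn with a defined configuration and the other without, at the place where they differ applies, and was within the scatter; it gives no direct guide to losing a hydrogen-bond donor and gaining a double bond outside aromatic rings. The expected step is therefore small, a 1.8-fold higher number from compound 2 to compound 3 (0.25 log units; within the scatter), with a wide range. Compound 3 is estimated at 250 nM, between 80 nM and 800 nM.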

Compound 3, half-maximal inhibitory concentration: 200 nM
For compound 3 the middle estimate is 1.3-fold (0.10 log units) above the measured one; low and high end bracket the measured number.
By their numbers in this assay, from the lowest: compounds 2, 1 and 3 (each within the scatter of the next).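

With the group that enters on the saturated chain carbon bound to a sulfur, which has 0 hydrogen-bond donors and 2 double bonds outside aromatic rings, the steps are small: a 1.4-fold higher number from compound 2 to compound 3 (0.15 log units; within the scatter) and a 1.2-fold higher number from compound 1 to compound 3 (0.07 log units; within the scatter) in this assay. At this place, then, the three compounds are not told apart, so the hydrogen-bond donor and the defined stereocentre of the group that leaves are not needed for a number in this range. Nothing known about these compounds bears on this change. On these data alone, whether a carboxylic acid or an amine on this carbon would also stay in this range remains open.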